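Replacing a benzyl ester with a triazolylmethyl on sulfur

This account rests on a few compounds, and the source may have more. Where it says the series, first, only, none or still open, it means among the compounds named here.

The compounds here share one core and differ at two places. Compound 1 `N#Cc1c(N)nc(SCC(N)=O)c(C#N)c1-c1ccc(OCC2CC2)cc1` gives 31 nM in a functional assay on CHO cells for agonist activity at adenosine receptor A2b (Homo sapiens), read by AlphaScreen and cAMP accumulation; on this read-out higher numbers stand for an effect only at larger amounts of compound and lower numbers for an effect already at smaller amounts. Compound 2 `COC(=O)c1cccc(CSc2nc(N)c(C#N)c(-c3ccc(OCC4CC4)cc3)c2C#N)c1` gives 347 nM and compound 3 `CC(=O)Nc1ccc(-c2c(C#N)c(N)nc(SCC(N)=O)c2C#N)cc1` gives 164 nM. Compound 2 therefore has the highest number of the three, above compound 3 and well above compound 1. Compound 4 `N#Cc1c(N)nc(SCc2ncn[nH]2)c(C#N)c1-c1ccc(OCC2CC2)cc1` differs from compound 2 by 1H-1,2,4-triazol-5-yl in place of 3-(methoxycarbonyl)phenyl on a saturated chain carbon bound to a sulfur. The step that bears on this place is an 11-fold higher number from compound 1 to compound 2 (1.05 log units; beyond the scatter), a large loss when the small carbamoyl was replaced by the larger ester-bearing ring; the step of a 5.3-fold higher number from compound 1 to compound 3 (0.72 log units; beyond the scatter) concerns a different place. The change to compound 4 brings back a small group with a hydrogen-bond donor, so a step back toward compound 1 is expected, namely a 5.8-fold lower number from compound 2 to compound 4 (0.76 log units; beyond the scatter). Compound 4 is thus estimated at 60 nM, within 20 nM to 200 nM.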

Compound 4, half-maximal effective concentration: 51 nM
For compound 4 the middle estimate is 1.2-fold (0.07 log units) above the measured one; measured number inside the range.
By their numbers in this assay, from the lowest: compounds 1 and 4 (each within the scatter of the next); then compound 3; then compound 2.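

Putting 1H-1,2,4-triazol-5-yl in place of 3-(methoxycarbonyl)phenyl gives a 6.8-fold lower number from compound 2 to compound 4 (0.83 log units; beyond the scatter), so the loss seen with compound 2 does not come with every ring on this saturated chain carbon bound to a sulfur. The ring also stands level with carbamoyl, at a 1.6-fold higher number from compound 1 to compound 4 (0.22 log units; within the scatter), so this assay does not separate these two groups. Nothing available here explains the difference between the two rings.

Still open, going by these compounds, is how a plain phenyl or a 3-carboxyphenyl would behave at this place. Also open, on these data alone, is whether 1-methyl-1,2,4-triazol-5-yl, with a methyl on the ring nitrogen, would match compound 4.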